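Fluoro to chloro on the sulfonyl aryl, second pair

The source may report more compounds than this note shows. Statements on the series, on what has been measured and on what is new or still open speak of the compounds shown alone.

In a functional assay on B16-F10 cells (Mus musculus) for antiproliferative activity, read by ELISA and MTT assay, with a stated time of 48 h (a lower number here means a stronger inhibitor, a higher number a weaker inhibitor), compound 1 `O=C(/C=C/c1ccc(Br)cc1)NS(=O)(=O)c1ccc(F)cc1` gives 1.2 ug/mL. Compound 2 `O=C(/C=C/c1ccc(Br)cc1)NS(=O)(=O)c1ccc(Cl)cc1` carries the change chloro in place of fluoro on an aromatic carbon and in this assay gives 5.2 ug/mL; the step is a 4.3-fold higher number from compound 1 to compound 2 (0.64 log units; beyond the scatter). Going by the values given here, compound 3 `O=C(/C=C/c1ccccc1[N+](=O)[O-])NS(=O)(=O)c1ccc(F)cc1` rests on a different core, and in this assay compound 3 gives 6 ug/mL, the highest of the three numbers so far; next to compound 2 the gap lies within the scatter, next to compound 1 it lies beyond it. The difference between the core of compound 1 and the core of compound 3 is not broken down here.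

Compound 4 `O=C(/C=C/c1ccccc1[N+](=O)[O-])NS(=O)(=O)c1ccc(Cl)cc1` has not yet been measured. It differs from compound 3 by chloro in place of fluoro on an aromatic carbon, which is the same change already made from compound 1 to compound 2, at the same place. Among the compounds with values here, only that one earlier instance of the change is available, so the expectation leans on it alone and is tempered toward a smaller step, since a single pair gives no sense of how well the shift carries over from one core to the other. The step from compound 3 to compound 4 in this assay is therefore estimated at a 3.3-fold higher number from compound 3 to compound 4 (0.52 log units; beyond the scatter), resting on the earlier step of a 4.3-fold higher number from compound 1 to compound 2 (0.64 log units; beyond the scatter). For compound 4 in this assay the expected value is 20 ug/mL, with a likely range from 7 ug/mL to 60 ug/mL.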

Compound 4, half-maximal inhibitory concentration: 6.6 ug/mL
Estimate against measurement, compound 4: 3.0-fold (0.48 log units) above; measured number below the stated range.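

In this assay, chloro in place of fluoro on the core of compound 3 gives a 1.1-fold higher number from compound 3 to compound 4 (0.04 log units; within the scatter), so compound 3 and compound 4 cannot be told apart, whereas the same change on the core of compound 1 produced a step beyond the scatter. The size of the step therefore does not carry over between these two cores, and the two instances disagree: the same change on two cores in this assay, a 4.3-fold higher number (0.64 log units; beyond the scatter) from compound 1 to compound 2 and a 1.1-fold higher number (0.04 log units; within the scatter) from compound 3 to compound 4, 3.9-fold (0.60 log units) apart, beyond the scatter of two such steps

This shows that, for these two pairs, the outcome of the change depends on the core that carries it, so a step read on one core is a poor guide to the other; it does not show what in the cores is responsible, nor which of the two steps would be the more typical on a third core.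

The compounds shown leave open whether a methyl or methoxy group on that same aromatic carbon would track the core of compound 1 or the core of compound 3. Also open, on these data alone, is how a core would respond to the fluoro and chloro pair if it carried an amine or a carboxylic acid in place of the bromo or nitro group.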